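Removing a chain methyl from an ester-linked naphthoquinone

The compounds below may be only part of what the source reports. "The series", "measured", "known", "first", "only" and "open" are said of these compounds alone.

Measured so far:
compound 1, `CC1=C(C(C)CC(=O)OCC(C)COc2no[n+]([O-])c2S(=O)(=O)c2ccccc2)C(=O)c2c(O)cccc2C1=O`: 3740 nM
compound 2, `CC1=C(CCC(=O)OCCOc2no[n+]([O-])c2S(=O)(=O)c2ccccc2)C(=O)c2c(O)cccc2C1=O`: 2980 nM
compound 3, `CC1=C(CCCC(=O)OCCOc2no[n+]([O-])c2S(=O)(=O)c2ccccc2)C(=O)c2c(O)cccc2C1=O`: 4160 nM

Three compounds built on a shared core, each carrying an ester chain that ends in the same sulfonyl-substituted ring, have been tested in a functional assay on HepG2 cells (Homo sapiens) for inhibition, read by MTT assay, with a stated time of 72 h; on this read-out lower numbers stand for stronger inhibition and higher numbers for weaker inhibition. Compound 1 gives 3740 nM in this assay. Compound 2, with a shorter linker and no chain methyl, gives 2980 nM, and compound 3, with one more chain carbon before the ester, gives 4160 nM. All three numbers lie within the usual scatter of one another, so none of them can be called stronger or weaker than the others on this evidence.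

Compound 4, `CC1=C(CCC(=O)OCC(C)COc2no[n+]([O-])c2S(=O)(=O)c2ccccc2)C(=O)c2c(O)cccc2C1=O`, has not yet been measured. It differs from compound 1 in one place: hydrogen in place of methyl on a saturated chain carbon bound to a double-bonded ring carbon and a saturated chain carbon. Among the measured compounds shown here, nothing among the measured compounds shows what this single change does on its own, since no two of them differ only in that way. The three measured compounds, with their differing chains, give numbers that all sit close together, which suggests that modest changes along the chain leave this assay little moved.

Compound 4 is therefore expected to land near compound 1, with a step of a 1.1-fold lower number from compound 1 to compound 4 (0.05 log units; within the scatter) that stays within the scatter. The estimate for compound 4 is 3300 nM, with a range from 1500 nM to 7500 nM.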

Compound 4, half-maximal inhibitory concentration: 6690 nM
Estimate against measurement, compound 4: 2.0-fold (0.31 log units) below, within the range that was stated.
By their numbers in this assay, from the lowest: compounds 2, 1, 3 and 4 (each within the scatter of the next, the first and the last beyond it).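

In this assay, among the compounds shown here, leaving hydrogen in place of the methyl on this saturated chain carbon gives a 1.8-fold higher number from compound 1 to compound 4 (0.25 log units; within the scatter), and this is the first reading of this single change on its own. A step of this size lies within the usual scatter of repeated measurements, so compound 1 and compound 4 cannot be put in order, and this pair gives no sign that the methyl at this place matters for the read-out, although a real but small effect cannot be ruled out either. Nothing at hand bears on what lies behind the step, so it stands here as a bare observation.

Whether a different group on the same carbon, such as an ethyl, a hydroxyl or a fluorine, would carry the number beyond the scatter remains an open question. It also remains open whether the same exchange of methyl for hydrogen would give a similar step on a longer chain, or on a chain ending in an amine rather than the ester seen in all of these compounds.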